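A few compounds are considered here, and "the series" means these few. Any claim that something is new, unique, unknown or untested is made for them only; others in the source may bear on it.

The account begins with compound 1, `COc1cc2ncnc(N3CCN(c4ccccc4OC)CC3)c2cc1OC`, which carries hydrogen on the aromatic carbon in question. In an in vitro assay on U2OS cells for agonist activity at neurotensin receptor type 2 (Homo sapiens), read by reporter gene assay and beta-arrestin recruitment (a lower number here means that less compound is needed, a higher number that more compound is needed for the effect), compound 1 reaches only the limit of the assay, > 80000 nM. Compound 2, `COc1cc2nc(Cc3ccccc3)nc(N3CCN(c4ccccc4OC)CC3)c2cc1OC`, carries a benzyl group in that place instead. In this assay compound 2 likewise returns only the limit, > 80000 nM. The step from compound 1 to compound 2, a step that the two limits leave unreadable from compound 1 to compound 2, therefore cannot be read, since both ends sit at the limit of > 80000 nM in this assay, at which 2 of the 2 values shown sit. Compound 3, `CCc1nc(N2CCN(c3ccccc3OC)CC2)c2cc(OC)c(OC)cc2n1`, is the next member and differs from compound 2 by methyl in place of phenyl on a saturated chain carbon bound to an aromatic carbon. Among the measured compounds shown here, no measured step speaks to this change directly; the only recorded step, the unreadable one just described, gives neither a size nor a direction, and the assay has so far produced no number at all for this series. Without any readable step to lean on, compound 3 is expected to behave like its neighbours, with a step that the limit leaves unreadable from compound 2 to compound 3 in this assay that is expected to stay within the scatter. Compound 3 is accordingly estimated at 100000 nM in this assay, within a range from 20000 nM to 500000 nM, with the likeliest outcome being that the assay once more reports only a limit.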

Compound 3, half-maximal effective concentration: > 80000 nM
Compound 3 ended at the assay's limit (the forecaster's own chance of this, stated with the estimate: 85%); the middle value lies beyond the limit too.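

No step can be read among compound 1, compound 2 and compound 3, since all three stop at the same limit and none gives a number: the limit of > 80000 nM in this assay, at which 3 of the 3 values shown sit. The compounds shown leave open whether hydrogen, benzyl or ethyl on that aromatic carbon makes any difference to the concentration needed in this assay.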